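The source may report more compounds than this note shows. Statements on the series, on what has been measured and on what is new or still open speak of the compounds shown alone.

Measured in a functional assay on K562 cells (Homo sapiens) for antiproliferative activity, read by MTT assay, with a stated time of 72 h; on this read-out higher numbers stand for weaker inhibition and lower numbers for stronger inhibition:
Compound 1 `COc1cc(C(=O)c2sc3ccccc3c2-c2ccc(F)cc2)cc(OC)c1OC`: 2100 nM
Compound 2 `COc1ccc(OC)c(-c2c(C(=O)c3cc(OC)c(OC)c(OC)c3)sc3ccccc23)c1`: > 10000 nM, a limit and not a number

Compound 2 stands at the limit of > 10000 nM in this assay, at which 1 of the 2 values shown sits, so only a limit is known for it. The next change leads to compound 3 `COc1ccc(-c2c(C(=O)c3cc(OC)c(OC)c(OC)c3)sc3ccccc23)cc1C`, with 4-methoxy-3-methylphenyl in place of 2,5-dimethoxyphenyl on an aromatic carbon. For the measured compounds named here, one measured step bears on this position: an at least 4.7-fold higher number from compound 1 to compound 2 (0.67 log units; beyond the scatter), which lies beyond the scatter and brought in the 2,5-dimethoxyphenyl group that now leaves. Going by the values given here, with only that step to go on, compound 3 is expected to return towards compound 1, which gives 2100 nM. The expected step in this assay is an at least 2.8-fold lower number from compound 2 to compound 3 (0.45 log units; beyond the scatter), towards a lower number and of modest size. For compound 3 the estimate is 3500 nM, with an expected range of 800 nM to 10000 nM.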

Compound 3, half-maximal inhibitory concentration: > 10000 nM
Compound 3 ended at the assay's limit; the forecaster's own chance of this, stated with the estimate: 25%; at least 2.8-fold (0.45 log units) between middle value and limit.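

In this assay, replacing 4-fluorophenyl with 4-methoxy-3-methylphenyl gives an at least 4.7-fold higher number from compound 1 to compound 3 (0.67 log units; beyond the scatter). The loss at this position is therefore not confined to the 2,5-dimethoxyphenyl group: two different methoxy-bearing phenyl groups now read weaker than the 4-fluorophenyl group of compound 1. The step from compound 2 to compound 3 cannot be read because both compounds sit at a limit and not at a number: the limit of > 10000 nM in this assay, at which 2 of the 3 values shown sit.

On these data alone, how far compound 2 and compound 3 lie past that limit remains unknown, so their two groups cannot be ranked against each other. Also open, as far as these compounds go, is whether a phenyl group carrying an amine or a carboxylic acid at this position would hold or improve on compound 1, at 2100 nM.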